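This account rests on a few compounds, and the source may have more. Where it says the series, first, only, none or still open, it means among the compounds named here.

Compound 2 `C=CC[C@H]1C[C@]2([C@@H](C)Cc3ccccc3)OCOC2=CC1=O` gives 5100 nM in a functional assay on M14 cells (Homo sapiens) for antiproliferative activity, with a stated time of 72 h (a higher number here means a weaker inhibitor, a lower number a stronger inhibitor), the highest of the two numbers in hand; compound 1 `C=CC[C@H]1C[C@]2([C@H](C)Cc3ccc(OC)c(OC)c3)OCOC2=CC1=O` gives 300 nM in this assay, a lower number beyond the scatter. Compound 3 `C=CC[C@H]1C[C@]2([C@@H](C)Cc3ccc(OC(F)(F)F)cc3)OCOC2=CC1=O` differs from compound 2 by trifluoromethoxy in place of hydrogen on an aromatic carbon, on an aromatic carbon of a six-membered aromatic ring of carbon only, para to a large group. Among the compounds with values here, no step between measured compounds isolates this change. Compound 3 is expected to show a lower number, with the step of a 3.4-fold lower number from compound 2 to compound 3 (0.53 log units; beyond the scatter) estimated to lie beyond the scatter. The estimate for compound 3 in this assay is 1500 nM, ranging from 400 nM to 6000 nM.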

Compound 3, half-maximal inhibitory concentration: > 20000 nM
Compound 3 ended at the assay's limit (the forecaster's own chance of this, stated with the estimate: 5%); at least 13-fold (1.12 log units) between middle value and limit.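

Trifluoromethoxy in place of hydrogen on an aromatic carbon, para to a large group, gives an at least 3.9-fold higher number from compound 2 to compound 3 (0.59 log units; beyond the scatter) in this assay, so in this series the change costs activity rather than improving it. The position is therefore sensitive to what it carries, and this group is not tolerated there. Compound 3 gives > 20000 nM, a limit and not a number: the limit of > 20000 nM in this assay, at which 1 of the 3 values shown sits.

The compounds shown leave open whether fluorine, an amine or a carboxylic acid at this position would keep activity. They also do not tell which feature of trifluoromethoxy matters.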